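Methylamino in place of propoxy on the shared core

The compounds below may be only part of what the source reports. "The series", "measured", "known", "first", "only" and "open" are said of these compounds alone.

In an ADME assay on BCBL1 cells (Homo sapiens) for cytotoxicity, with a stated time of 7 days (a higher number here means that more compound is tolerated, a lower number that less compound is tolerated), compound 1 `CCCNc1nc(N)nc2c1ncn2/C=C1/CC1(CO)CO` gives only a limit, > 20000 nM. Compound 2 `CCCOc1nc(N)nc2c1ncn2/C=C1/CC1(CO)CO` likewise returns only a limit in this assay, > 20000 nM. Compound 3 `CCCCCCSc1nc(N)nc2c1ncn2/C=C1/CC1(CO)CO` also stops at a limit, > 20000 nM. All three values sit at the limit of > 20000 nM in this assay, at which 3 of the 3 values shown sit, so the steps a step that the two limits leave unreadable from compound 1 to compound 2, a step that the two limits leave unreadable from compound 1 to compound 3 and a step that the two limits leave unreadable from compound 2 to compound 3 carry no readable size or direction. Compound 4 `CNc1nc(N)nc2c1ncn2/C=C1/CC1(CO)CO` is not yet measured in this assay; it differs from compound 2 by methylamino in place of propoxy on an aromatic carbon. Within the data shown here, none of the measured steps bears on a change of this kind, and the three limits give no basis for expecting movement either way. Compound 4 is therefore expected to show a step of a number no higher from compound 2 to compound 4 (the limit leaves the size open) of no more than the scatter, most likely as another limit. The estimate for compound 4 is 20000 nM, within 10000 nM to 60000 nM.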

Compound 4, half-maximal cytotoxic concentration: 67000 nM
Compound 4: the middle estimate sits 3.4-fold (0.53 log units) below what was measured; measured number outside the range, above it.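

Among these compounds, no step linking compound 4 with compound 1, compound 2 or compound 3 can be read, because those three compounds stop at a limit: the limit of > 20000 nM in this assay, at which 3 of the 4 values shown sit. The compounds shown leave open whether, in this assay, any of these changes on the shared core moves the read-out.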